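Removing One Methoxy Group: Cytotoxicity Expected to Stay Flat

A few compounds are considered here, and "the series" means these few. Any claim that something is new, unique, unknown or untested is made for them only; others in the source may bear on it.

Compound 1, `O=C(c1ccccc1)C1CCN(Cc2coc(-c3ccc(F)cc3)n2)CC1`, gives > 150 ug/mL in an ADME assay on HEK293 cells (Homo sapiens) for cytotoxicity, read by MTT assay, with a stated time of 36 h; on this read-out lower numbers stand for stronger inhibition and higher numbers for weaker inhibition; this value is a limit of the assay, not a number.
Compound 2, `COc1ccc(C(=O)C2CCN(Cc3coc(-c4ccc(F)cc4)n3)CC2)cc1OC`, gives > 150 ug/mL in this assay; this too is a limit.

Compound 2 therefore stands only at a limit, and the other value shown is a limit as well. Within the data shown here, the single measured step, a step that the two limits leave unreadable from compound 1 to compound 2, cannot be read in size because both ends sit at the limit, as the limit of > 150 ug/mL in this assay, at which 2 of the 2 values shown sit, records. The next change is hydrogen in place of methoxy on an aromatic carbon, which turns compound 2 into compound 3, `COc1ccc(C(=O)C2CCN(Cc3coc(-c4ccc(F)cc4)n3)CC2)cc1`. Among the measured compounds shown here, no measured step bears on this change, so the expectation rests on the two limits alone. The step that the limit leaves unreadable from compound 2 to compound 3 is expected to show nothing beyond the usual scatter, with compound 3 most likely again reported as a limit. Compound 3 is estimated at 200 ug/mL, within a range from 100 ug/mL to 600 ug/mL.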

Compound 3, half-maximal inhibitory concentration: > 150 ug/mL
Compound 3: only a limit was reported (the forecaster's own chance of this, stated with the estimate: 85%); the middle value does not contradict the limit.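

No step among compound 1, compound 2 and compound 3 can be read in size, because all three values are limits of the assay rather than numbers: the limit of > 150 ug/mL in this assay, at which 3 of the 3 values shown sit.

The compounds shown leave open how cytotoxic each one really is, and whether a methoxy group changes that at all.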